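The source may hold more compounds than are shown below. What is called first, only, known or untested is meant among the compounds shown, and "the series" means these compounds.

Within the data shown here, compound 1 `COc1ccc(-n2cnc3cnc(-c4ccc(F)cc4C)cc32)cc1` is the only member of this set with a number to its name: in an ADME assay on S9 fraction from liver (Mus musculus) for metabolic stability, read by LC-MS, using NADPH, with a stated time of 45 min, tested at 3 uM, in the presence of a further agent that is not named here (a higher number here means that the liver removes a larger share of the compound in one pass, a lower number that the liver removes a smaller share), compound 1 gives 1. Compound 2 `COc1ccc(-n2cnc3cnc(-c4ccc(F)cc4C)cc32)cc1C(C)C` carries no result, as in this assay compound 2 gives "not determined" (no result reported). Compound 3 `COc1ccc(-n2cnc3cnc(-c4ccc(F)cc4C)cc32)cn1` differs from compound 1 by 6-methoxypyridin-3-yl in place of 4-methoxyphenyl on an aromatic nitrogen. Among the measured compounds shown here, no step between measured compounds is known, so the expectation rests on compound 1 alone. Since compound 1 stands at 1, compound 3 is expected to move modestly downward or not beyond the scatter, a number 0.15 lower from compound 1 to compound 3 (beyond the scatter). Compound 3 is therefore estimated at 0.85, within 0.6 to 1.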

Compound 3, hepatic extraction ratio: 0.39
Estimate against measurement, compound 3: 0.46 above; the measured number lies below the stated range.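

In this assay, 6-methoxypyridin-3-yl in place of 4-methoxyphenyl on an aromatic nitrogen gives a number 0.61 lower from compound 1 to compound 3 (beyond the scatter), the first sign that the read-out depends on the group at this position. The two groups have the same number of heavy atoms, and the entering ring holds one nitrogen where the leaving ring holds only carbon, so a change this small within the ring is enough for a large step. Nothing measured here explains why the number falls.

Going by these compounds, it remains open whether the ring nitrogen alone carries this step on other substituted rings at this position. On these data alone, it is also open whether an amine or a longer ether chain in place of the methoxy group of compound 3 would hold the number at this level.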